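Replacing the Difluorophenyl Group with Pyrimidin-2-yl

The source may report more compounds than this note shows. Statements on the series, on what has been measured and on what is new or still open speak of the compounds shown alone.

Compound 1 `Nc1nc(N)c2cc(CSC(=S)N3CCN(c4ccccc4)CC3)ccc2n1`: 2950 nM
Compound 2 `Nc1nc(N)c2cc(CSC(=S)N3CCN(c4ccc(Cl)cc4)CC3)ccc2n1`: 4880 nM
Compound 3 `Nc1nc(N)c2cc(CSC(=S)N3CCN(c4ccc(F)cc4F)CC3)ccc2n1`: 3670 nM
Compound 4 `Nc1nc(N)c2cc(CSC(=S)N3CCN(c4ncccn4)CC3)ccc2n1`: not yet measured

All three measured values come from a functional assay on MCF7 cells (Homo sapiens) for antiproliferative activity, read by MTT assay, with a stated time of 72 h (on this read-out lower numbers stand for stronger inhibition and higher numbers for weaker inhibition), and lie close together. Compound 3 cannot be told apart from the other two compounds, with a 1.2-fold higher number from compound 1 to compound 3 (0.09 log units; within the scatter) and a 1.3-fold lower number from compound 2 to compound 3 (0.12 log units; within the scatter) as its measured steps.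

The next step changes one group. Compound 4 carries pyrimidin-2-yl in place of 2,4-difluorophenyl on an amine nitrogen in a ring. The measured steps that bear on this change all alter the aromatic group at that same place. Alongside the two above stands a 1.7-fold higher number from compound 1 to compound 2 (0.22 log units; within the scatter) and none of the three leaves the scatter. However, every measured compound has a ring of carbon only there, so no measured step tests hetero atoms in that ring directly. The expectation is therefore loose: no shift beyond the scatter, and no firm direction in this assay. The expected change is a 1.0-fold lower number from compound 3 to compound 4 (0.02 log units; within the scatter) as an estimate with wide uncertainty. Compound 4 is estimated at 3500 nM (expected range 1500 nM to 8000 nM).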

Compound 4, half-maximal inhibitory concentration: 4190 nM
The estimate for compound 4 lay 1.2-fold (0.08 log units) below the measured number, within the range that was stated.
By their numbers in this assay, from the lowest: compounds 1, 3, 4 and 2 (each within the scatter of the next).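

Among these compounds, compound 4 is the first compound here with hetero atoms in the aromatic ring on the amine nitrogen, and in this assay this change gives a step that stays within the scatter (a 1.1-fold higher number from compound 3 to compound 4 (0.06 log units; within the scatter)). The steps from the other two carbon-only rings also stay within the scatter (a 1.2-fold lower number from compound 2 to compound 4 (0.07 log units; within the scatter); a 1.4-fold higher number from compound 1 to compound 4 (0.15 log units; within the scatter)), so across these four compounds, swapping in pyrimidin-2-yl, with its 2 hydrogen-bond acceptors where 2,4-difluorophenyl has none, produces no shift that can be told apart from ordinary repeat variation. No supporting measurement is available to explain this flat result.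

From the compounds shown here alone, all four groups at this position are six-membered aromatic rings, so it remains open what a non-aromatic group such as cyclohexyl, a small group such as methyl, or a longer link such as benzyl would do on that nitrogen. Going by these compounds, it is also open whether pyridin-2-yl would fall just as close to these compounds, and whether pyrimidin-2-yl and the carbon-only rings would stay this close on cells other than those used here.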